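Swapping the Ester for a Nitro Group on Compound 1

This account rests on a few compounds, and the source may have more. Where it says the series, first, only, none or still open, it means among the compounds named here.

Of the compounds shown here, three sharing one core have been measured in a functional assay on MCF7 cells (Homo sapiens) for inhibition; a higher number here means a weaker inhibitor, a lower number a stronger inhibitor. Compound 1 `CCOC(=O)c1ccc(NC(=O)N2CC2C#N)cc1` carries an ethoxycarbonyl group on its aromatic ring and gives 2100 nM in this assay. Compound 2 `N#CC1CN1C(=O)NCc1ccccc1` gives 6000 nM, and compound 3 `N#CC1CN1C(=O)Nc1cccnc1` gives 6600 nM. Compound 1 thus has the lowest number of the three, which makes it the strongest inhibitor of this small set; its nearest neighbour is compound 2, and both compound 2 and compound 3 lie beyond the usual scatter from it.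

The unmeasured compound 4 `N#CC1CN1C(=O)Nc1ccc([N+](=O)[O-])cc1` is compound 1 with a single change: nitro in place of ethoxycarbonyl on an aromatic carbon. The ethoxycarbonyl leaves, a nitro enters on the aromatic carbon, and the core is untouched. For the measured compounds named here, no measured pair in this set isolates a swap of this kind, so the data give no direct guide to its effect.

The step from compound 1 to compound 4 is expected to be small, a 1.2-fold higher number from compound 1 to compound 4 (0.08 log units; within the scatter), most likely within the usual scatter and with no confident direction. Compound 4 is therefore expected to give about 2500 nM in this assay, with a plausible range from 900 nM to 7000 nM.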

Compound 4, half-maximal inhibitory concentration: 3000 nM
The estimate for compound 4 lay 1.2-fold (0.08 log units) below the measured number; measured number inside the range.
By their numbers in this assay, from the lowest: compounds 1, 4, 2 and 3 (each within the scatter of the next, the first and the last beyond it).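

In this assay the swap of ethoxycarbonyl for nitro, on the aromatic carbon para to a group of 8 heavy atoms, gives a 1.4-fold higher number from compound 1 to compound 4 (0.15 log units; within the scatter) and so leaves compound 1 and compound 4 indistinguishable in this measurement. For the compounds shown here, this is the first pair in the set that differs in one place, and it offers the first direct reading at this position: a substituent of 5 heavy atoms and one of 3 heavy atoms, each counted with 2 hydrogen-bond acceptors and 0 hydrogen-bond donors, can replace each other here without a change that stands out from the scatter. The data offer no measured explanation for this result.

A single swap says little about how much freedom this position allows overall, since the two groups compared match in their counted acceptors and donors and neither carries a net charge. From the compounds shown here alone, whether the number would hold with an amine, a carboxylic acid, a longer ester chain or a bare hydrogen at this aromatic carbon remains open.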